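The compounds below may be only part of what the source reports. "The series", "measured", "known", "first", "only" and "open" are said of these compounds alone.

Working notes on the carboxamide series.

Compound 1 `CNc1cc(C(N)=O)ccc1-n1nc(C(C)C)c2c(-n3cnc(-c4cnn(C)c4)c3)ccnc21` is the reference point; in a physicochemical assay for solubility, at pH 7.4 (a lower number here means a less soluble compound, a higher number a more soluble compound), compound 1 gives 15000 nM. Compound 2 `CNc1cc(-n2nc(C(C)C)c3c(-n4cnc(-c5cnn(C)c5)c4)ccnc32)ccc1C(N)=O` carries the same groups on a 4-carbamoyl-3-(methylamino)phenyl instead of the 4-carbamoyl-2-(methylamino)phenyl. For compound 2 the this assay reading is only a limit, < 2000 nM. The step of an at least 7.5-fold lower number from compound 1 to compound 2 (0.87 log units; beyond the scatter) therefore shows a drop, its size bounded because compound 2 sits at the limit of < 2000 nM in this assay, at which 1 of the 2 values shown sits.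

Compound 3 `CC(C)c1nn(-c2ccc(C(N)=O)cc2)c2nccc(-n3cnc(-c4cnn(C)c4)c3)c12` follows from compound 2 by the change (hydrogen in place of methylamino on an aromatic carbon). For the measured compounds named here, no measured step concerns the loss of the methylamino group, so the one step in hand, a repositioning of that group, gives no direct guide. Going by the values given here, compound 2 already stands at the floor of this assay, and the sole expectation for compound 3 is that it stays in the same low region, with the step of a number no lower from compound 2 to compound 3 (the limit leaves the size open) estimated as small. The estimate for compound 3 in this assay is 2000 nM, within a range of 500 nM to 8000 nM.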

Compound 3, solubility: 4000 nM
Estimate against measurement, compound 3: 2.0-fold (0.30 log units) below; measured number inside the range.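

In this assay, hydrogen in place of methylamino on the 4-carbamoyl-3-(methylamino)phenyl gives an at least 2.0-fold higher number from compound 2 to compound 3 (0.30 log units; that floor lies within the scatter), so this replacement is not shown to change the reading beyond the scatter. As far as these compounds go, the size of that step stays open because compound 2 is held at a limit: the limit of < 2000 nM in this assay, at which 1 of the 3 values shown sits. The same replacement read from the 4-carbamoyl-2-(methylamino)phenyl gives a 3.8-fold lower number from compound 1 to compound 3 (0.57 log units; beyond the scatter), so the 4-carbamoylphenyl is clearly lower than the 4-carbamoyl-2-(methylamino)phenyl and only that placement of methylamino stands clearly apart from hydrogen.

From the compounds shown here alone, the actual reading of compound 2 remains unknown, so the direction of its step to hydrogen is only bounded. Going by these compounds, what a primary amine or a methoxy group would give in place of the methylamino in this assay also remains open.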